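A few compounds are considered here, and "the series" means these few. Any claim that something is new, unique, unknown or untested is made for them only; others in the source may bear on it.

Working notes on the series.

Two members of the series carry a measurement in a functional assay on MDA-MB-231 cells (Homo sapiens) for cytotoxicity, read by MTT assay, with a stated time of 72 h; a higher number here means a weaker inhibitor, a lower number a stronger inhibitor. Compound 1 `CN1CCN(CCCCCn2c3c(c4ccccc42)C(=O)c2c[n+]([O-])c4ccccc4c2C3=O)CC1` gives 2270 nM in this assay. Compound 2 `O=C1c2c[n+]([O-])c3ccccc3c2C(=O)c2c1c1ccccc1n2Cc1cn([C@H]2C[C@H](O)[C@@H](CO)O2)nn1` gives 580 nM in this assay, the lowest of the two numbers recorded; the gap to compound 1, whose number is the higher one, lies beyond the usual scatter of the assay. Within the data shown here, no pair of measured compounds differs in a single place, so no single-change step can be read off the measured set.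

Compound 3 `CC1(C)O[C@@H](CO)[C@H](Cn2cc(Cn3c4c(c5ccccc53)C(=O)c3c[n+]([O-])c5ccccc5c3C4=O)nn2)O1` is the next member to be measured in this assay. It differs from compound 2 in one place ((5-(hydroxymethyl)-2,2-dimethyl-1,3-dioxolan-4-yl)methyl in place of 4-hydroxy-5-(hydroxymethyl)oxolan-2-yl on an aromatic nitrogen). The group that leaves carries two hydrogen-bond donors, the group that enters carries one; what this change does in this assay cannot be read from the two measured compounds, since no comparable change is recorded.

For compound 3 the step from compound 2 is expected to be modest and towards a higher number, a 2.4-fold higher number from compound 2 to compound 3 (0.38 log units; beyond the scatter). Compound 3 is estimated at 1400 nM, within a range from 500 nM to 4000 nM.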

Compound 3, half-maximal inhibitory concentration: 680 nM
The estimate for compound 3 lay 2.1-fold (0.31 log units) above the measured number; low and high end bracket the measured number.
By their numbers in this assay, from the lowest: compounds 2 and 3 (each within the scatter of the next); then compound 1.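

Among these compounds, on the aromatic nitrogen of the five-membered aromatic ring with 3 nitrogen, (5-(hydroxymethyl)-2,2-dimethyl-1,3-dioxolan-4-yl)methyl in place of 4-hydroxy-5-(hydroxymethyl)oxolan-2-yl gives a 1.2-fold higher number from compound 2 to compound 3 (0.07 log units; within the scatter) in this assay, which is the first single-change step available. At this position, then, a ring with 2 hetero atoms carried on a methyl link, with 1 hydrogen-bond donor and 2 defined stereocentres, reads the same within the scatter as a ring with 1 hetero atom, 2 hydrogen-bond donors and 3 defined stereocentres. No measurement at hand accounts for this result.

On these data alone, both groups in this step are oxygen-bearing rings, so it remains open how this assay responds at this position to a carboxylic acid, a primary amine or a plain butyl chain in their place. Compound 1 differs from compound 2 and compound 3 in more than one place, so its number cannot yet be assigned to any single feature, and a piperazine carried on the triazole-linked side remains an open comparison.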